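Swapping Isopropyl for Ethylamino on a Carbonyl Carbon

This account rests on a few compounds, and the source may have more. Where it says the series, first, only, none or still open, it means among the compounds named here.

For the measured compounds named here, in a functional assay on A2780 cells (Homo sapiens) for cytotoxicity (a higher number here means a weaker inhibitor, a lower number a stronger inhibitor), compound 1 `CC(C)C(=O)Nc1ncc(SCc2ncc(C(C)(C)C)o2)s1` gives 50 nM and holds the lower of the two numbers so far. Compound 2 `CC(C)(C)c1cnc(CSc2cnc(NS(=O)(=O)c3ccccc3)s2)o1` at 2860 nM sits higher, beyond the usual scatter. Compound 3 `CCNC(=O)Nc1ncc(SCc2ncc(C(C)(C)C)o2)s1` has not yet been measured and carries ethylamino in place of isopropyl on a carbonyl carbon with the rest of compound 1 unchanged. Going by the values given here, no measured pair shows this swap. In this assay a modest rise is expected, the estimated 2.4-fold higher number from compound 1 to compound 3 (0.38 log units; beyond the scatter) pointing towards a somewhat weaker inhibitor. For compound 3 the expected value is 120 nM (estimated range 35 nM to 450 nM).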

Compound 3, half-maximal inhibitory concentration: 120 nM
Estimate against measurement, compound 3: no gap at the digits printed; measured number inside the range.
By their numbers in this assay, from the lowest: compound 1; then compound 3; then compound 2.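

Within this assay, this is the first direct reading at this position: ethylamino in place of isopropyl on a carbonyl carbon gives a 2.4-fold higher number from compound 1 to compound 3 (0.38 log units; beyond the scatter) while the rest of compound 1 stays unchanged. The position therefore responds to the swap, but the loss is modest. The change keeps the count of 3 heavy atoms, exchanges one carbon for nitrogen and adds 1 hydrogen-bond donor, yet no evidence here accounts for the rise. Still open, from the compounds shown here alone, is how dimethylamino or a longer chain such as butylamino would fare on this carbonyl carbon, and so whether the added donor matters to the step.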